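This account rests on a few compounds, and the source may have more. Where it says the series, first, only, none or still open, it means among the compounds named here.

Working notes on the series. Of the compounds shown here, three sharing one core have been read in a functional assay on the whole organism (strain albino) for inhibition, with Rattus norvegicus as the target, read by paw edema, with stated times of 30 min and 1 h, at a dose of 5 mg/kg by the oral route; a higher number here means more inhibition at the dose given (going by the name of the read-out), a lower number less inhibition. Compound 1 `CCOC(=O)Cc1n[nH]c(N)n1` gives 25% in this assay. Compound 2 `CCOC(=O)Cc1nc(N)n(C(=O)c2ccc(OC)cc2)n1` gives 32.8%. Compound 3 `CCOC(=O)Cc1n[nH]c(NC(=O)c2ccccc2)n1` gives 26.8%. Compound 3 stands second highest of the three numbers: its nearest neighbour is compound 1, whose number is lower by an amount within the usual scatter, and the furthest is compound 2, whose number is higher, also within the scatter. The three values sit together and no order among them can be read.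

Next is compound 4 `CCOC(=O)Cc1n[nH]c(NC(=O)c2ccc(OC)cc2)n1`. Against compound 3 the change is methoxy in place of hydrogen on an aromatic carbon, on an aromatic carbon of a six-membered aromatic ring of carbon only. Among the measured compounds shown here, no measured pair shows this change alone. Compound 2 also carries a methoxy group, in a different arrangement, and its value lies within the scatter of compound 3, so nothing points to a large step. The expected step in this assay, if any, is small and not beyond the scatter, leaning slightly upward. The estimated step of a number 3.2 percentage points higher from compound 3 to compound 4 (within the scatter) reflects this. Compound 4 is therefore expected to give about 30%, between 20% and 40%.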

Compound 4, a percentage reported as inhibition, in the whole organism at one dose (the size of the read-out at that dose, not a potency): 30.2%
Compound 4: middle estimate off by 0.2 percentage points, on the low side, within the range that was stated.
By their numbers in this assay, from the lowest: compounds 1, 3, 4 and 2 (each within the scatter of the next).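

Among the compounds shown here, compound 3 and compound 4 form the first pair that shows methoxy in place of hydrogen on an aromatic carbon alone. In this assay the change gives a number 3.4 percentage points higher from compound 3 to compound 4 (within the scatter), so at this place, para to a large group, the read-out does not separate methoxy from hydrogen. Nothing at hand bears on a cause for this result.

A single substituent at this place cannot show whether the position is insensitive in general or only to this one exchange. Open, on these data alone, is whether an amine, a carboxylic acid or a longer chain at the same aromatic carbon would give a step beyond the scatter, or would likewise leave the number within it.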